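A few compounds are considered here, and "the series" means these few. Any claim that something is new, unique, unknown or untested is made for them only; others in the source may bear on it.

Measured so far:
- compound 1 `N[C@H]1CC[C@H](Nc2c(C(=O)NCc3ccco3)nc(Br)c3cccnc23)CC1`: in a functional assay on HEY cells (Homo sapiens) for cytotoxicity, read by MTT assay, with a stated time of 72 h (a higher number here means a weaker inhibitor, a lower number a stronger inhibitor), compound 1 gives > 10000 nM, which is a limit of the assay.
- compound 2 `N[C@H]1CC[C@H](Nc2c(C(=O)NCc3ccc(F)cc3)nc(Br)c3cccnc23)CC1`: in this assay compound 2 gives "not determined" (no result reported).
- compound 3 `COC(=O)c1nc(Br)c2cccnc2c1N[C@H]1CC[C@H](N)CC1`: in this assay compound 3 gives > 20000 nM, which is likewise a limit of the assay.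

Compound 1 therefore stands nowhere in particular on the numbers shown: its own result is only a limit, one further result is also a limit, and the remaining entry has no number at all. Going by the values given here, the single step between measured compounds, a step that the two limits leave unreadable from compound 1 to compound 3, cannot be read, since both of its ends are limits, as the limit of > 10000 nM in this assay, at which 1 of the 3 values shown sits, and the limit of > 20000 nM in this assay, at which 1 of the 3 values shown sits, show.

The compound that follows is compound 4 `N[C@H]1CC[C@H](Nc2c(C(=O)NC3CCCCC3)nc(Br)c3cccnc23)CC1`. It differs from compound 1 by cyclohexyl in place of (furan-2-yl)methyl on an amide-type nitrogen. Among the compounds with values here, no measured step bears on this change; the only step available is unreadable, so nothing indicates a readable shift in either direction in this assay. Compound 4 is accordingly expected to sit at 15000 nM, within a range from 4000 nM to 60000 nM, and most likely to be reported again as a limit. The step this estimate means, a step that the limit leaves unreadable from compound 1 to compound 4, is expected to stay within the scatter.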

Compound 4, half-maximal inhibitory concentration: 5200 nM
Compound 4: the middle estimate sits 2.9-fold (0.46 log units) above what was measured, within the range that was stated.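

In this assay, going by these compounds alone, compound 4 gives 5200 nM and is the first compound here with a result that is a number, not a limit or an empty entry. Cyclohexyl in place of (furan-2-yl)methyl on the amide-type nitrogen gives an at least 1.9-fold lower number from compound 1 to compound 4 (0.28 log units; that floor lies within the scatter) and, as this is only a floor, a real change cannot be claimed, because the result of compound 1 is a limit of the assay: the limit of > 10000 nM in this assay, at which 1 of the 4 values shown sits. Cyclohexylamino in place of methoxy on the carbonyl carbon gives an at least 3.8-fold lower number from compound 3 to compound 4 (0.58 log units; beyond the scatter), so the group on this carbonyl carbon does register in the read-out, even though the result of compound 3 is likewise a limit of the assay: the limit of > 20000 nM in this assay, at which 1 of the 4 values shown sits.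

As far as these compounds go, how far the number moves with other groups on this amide-type nitrogen remains open, for instance with a short ethyl chain, a phenyl ring or a longer chain ending in an amine, and the fluorinated benzyl amide of compound 2 offers no number to help. Whether a carboxylic acid on the carbonyl carbon or a chlorine in place of the bromine would shift the result also stays unanswered.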